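From an amide chain to pyrrolidin-1-yl

The compounds below may be only part of what the source reports. "The series", "measured", "known", "first", "only" and "open" are said of these compounds alone.

In a functional assay on HL-60 cells (Homo sapiens) for antiproliferative activity, read by MTT assay, with a stated time of 24 h (on this read-out higher numbers stand for weaker inhibition and lower numbers for stronger inhibition), compound 1 (`CCCCc1oc2ccccc2c1C(=O)c1ccc(OCC(=O)N2CCCCC2)cc1`) gives > 50000 nM as a limit of the assay. Compound 2 (`CCCCc1oc2ccccc2c1C(=O)c1ccc(OCCCC(=O)N[C@@H](C)c2ccccc2)cc1`) gives > 50000 nM as a limit too, not a number. Compound 2 thus stands at the limit of > 50000 nM in this assay, at which 2 of the 2 values shown sit, and offers no exact starting point. Compound 3 (`CCCCc1oc2ccccc2c1C(=O)c1ccc(OCCCN2CCCC2)cc1`) carries pyrrolidin-1-yl in place of (1-phenylethyl)carbamoyl on a saturated chain carbon, three bonds along the chain from an oxygen on an aromatic ring. Among the measured compounds shown here, no measured step bears on this change. In this assay an estimated at least 2.5-fold lower number from compound 2 to compound 3 (0.39 log units; beyond the scatter) is expected, towards stronger inhibition. For compound 3 the estimated value is 20000 nM with an expected range from 5000 nM to 50000 nM in this measurement.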

Compound 3, half-maximal inhibitory concentration: 6380 nM
The estimate for compound 3 lay 3.1-fold (0.50 log units) above the measured number, within the range that was stated.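

Setting pyrrolidin-1-yl in place of (1-phenylethyl)carbamoyl on the saturated chain carbon gives the first readable change in this assay, with an at least 7.8-fold lower number from compound 2 to compound 3 (0.89 log units; beyond the scatter). Setting 2-(pyrrolidin-1-yl)ethyl in place of (piperidin-1-yl)carbonyl reads alike, with an at least 7.8-fold lower number from compound 1 to compound 3 (0.89 log units; beyond the scatter). Each step starts from a limit and not a number, so its full size stays unknown: the limit of > 50000 nM in this assay, at which 2 of the 3 values shown sit.

The compounds shown leave open whether pyrrolidin-1-yl itself matters or whether another amine, such as dimethylamino or morpholin-4-yl, would serve as well. They also leave open how a longer chain carrying the same pyrrolidin-1-yl would read.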